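Adamantane trioxolane quinolines: Caco-2 tolerance, methyl for trifluoromethyl

This account rests on a few compounds, and the source may have more. Where it says the series, first, only, none or still open, it means among the compounds named here.

Measured compounds:
- compound 1, `COc1cc(NC(C)CCCNCC2CCC3(CC2)OOC2(OO3)C3CC4CC(C3)CC2C4)c2ncccc2c1-c1ccccc1`: in an ADME assay on Caco-2 cells (Homo sapiens) for cytotoxicity, read by neutral red uptake, with a stated time of 72 h (a higher number here means that more compound is tolerated, a lower number that less compound is tolerated), compound 1 gives "not determined" (no result reported)
- compound 2, `COc1cc(NC(C)CCCNCC2CCC3(CC2)OOC2(OO3)C3CC4CC(C3)CC2C4)c2ncccc2c1-c1ccc(F)cc1`: in this assay compound 2 gives "not determined" (no result reported)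
- compound 3, `COc1cc(NC(C)CCCNCC2CCC3(CC2)OOC2(OO3)C3CC4CC(C3)CC2C4)c2ncccc2c1-c1ccc(C(F)(F)F)cc1`: 10300 nM

Three compounds of the series share the same core and differ only in the substituent on the pendant phenyl ring. For compound 1 and compound 2 no number is available in this assay; compound 3 therefore provides the only measured point, with the half-maximal cytotoxic concentration given above. Within the data shown here, with a single value there is no measured step, and no ordering among the three can be stated.

Compound 4, `COc1cc(NC(C)CCCNCC2CCC3(CC2)OOC2(OO3)C3CC4CC(C3)CC2C4)c2ncccc2c1-c1ccc(C)cc1`, is the next member to be measured. Relative to compound 3 the change is methyl in place of trifluoromethyl on an aromatic carbon. Among the measured compounds shown here, no measured pair shows what such a swap on this phenyl ring does to tolerance in this assay, so the expectation rests on compound 3 alone.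

The step from compound 3 to compound 4 is expected to stay within the usual scatter of the assay, with no clear direction; the estimated step is a 1.2-fold higher number from compound 3 to compound 4 (0.07 log units; within the scatter). For compound 4 the half-maximal cytotoxic concentration in this assay is accordingly estimated at 12000 nM, in a range from 4000 nM to 36000 nM.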

Compound 4, half-maximal cytotoxic concentration: 11700 nM
Estimate against measurement, compound 4: 1.0-fold (0.01 log units) above, and the stated range covers the measured number.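

In this assay, the series now has its first readable step at this position: methyl in place of trifluoromethyl on the aromatic carbon of the phenyl ring gives a 1.1-fold higher number from compound 3 to compound 4 (0.06 log units; within the scatter). The two values therefore cannot be separated, and in this one pair, going from 4-(trifluoromethyl)phenyl to 4-methylphenyl, which takes the substituent from 4 heavy atoms to 1 and removes all 3 fluorine atoms, leaves no distinguishable effect on tolerance. No supporting measurement is available to explain this match.

Steps involving compound 1 and compound 2 cannot be read, so this single pair gives no trend across the phenyl substituents and does not show how either compound compares with compound 3 or compound 4. Also open, going by these compounds, is whether a different kind of group on this aromatic carbon, such as an amine, a carboxylic acid or a longer alkyl chain, would stay within the scatter of compound 3 or produce a clear step in this assay.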